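Swapping the methoxy for fluoro on the aryl substituent

The compounds below may be only part of what the source reports. "The series", "measured", "known", "first", "only" and "open" are said of these compounds alone.

Of the compounds shown here, three have been measured in a functional assay on MCF7 cells (Homo sapiens) for antiproliferative activity, read by MTT assay, with a stated time of 72 h; on this read-out lower numbers stand for stronger inhibition and higher numbers for weaker inhibition. Compound 1 `COc1ncc(-c2ccc3c(c2)N(c2ccc(C)cc2)C(=O)CO3)cc1NS(=O)(=O)c1ccc(F)cc1` gives 15400 nM. Compound 2 `O=C1COc2ccc(-c3cccc(NS(=O)(=O)c4ccc(F)cc4)c3)cc2N1c1ccccc1` gives only a limit of the assay, > 40000 nM; (the limit of > 40000 nM in this assay, at which 1 of the 3 values shown sits). Compound 3 `COc1ccc(N2C(=O)COc3ccc(-c4cnc(OC)c(NS(=O)(=O)c5ccc(F)cc5)c4)cc32)cc1` gives 8260 nM, the lowest of the two numbers recorded in this assay, though its step from compound 1 is small: a 1.9-fold lower number from compound 1 to compound 3 (0.27 log units; within the scatter).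

Compound 4 `COc1ncc(-c2ccc3c(c2)N(c2ccc(F)cc2)C(=O)CO3)cc1NS(=O)(=O)c1ccc(F)cc1` has not yet been measured. Its difference from compound 3 is fluoro in place of methoxy on an aromatic carbon. Among the measured compounds shown here, the only measured step that touches this part of the molecule is the one from compound 1 to compound 3, which stayed within the scatter of this assay. For the measured compounds named here, no measured pair shows fluoro in place of methoxy, so nothing in the data points to a step beyond the scatter in either direction. The expected value for compound 4 in this assay is therefore 12000 nM, with a range from 4000 nM to 40000 nM, and the expected step from compound 3 is a 1.5-fold higher number from compound 3 to compound 4 (0.16 log units; within the scatter).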

Compound 4, half-maximal inhibitory concentration: > 40000 nM
Compound 4 ended at the assay's limit (the forecaster's own chance of this, stated with the estimate: 15%); middle value at least 3.3-fold (0.52 log units) away from the limit.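

This position is not indifferent to its substituent: the change from 4-methoxyphenyl to 4-fluorophenyl gives an at least 4.8-fold higher number from compound 3 to compound 4 (0.68 log units; beyond the scatter), whereas the earlier step of methoxy in place of methyl stayed within the scatter. Fluoro in place of methyl also moves the number beyond the scatter, with an at least 2.5-fold higher number from compound 1 to compound 4 (0.41 log units; beyond the scatter), so among these three compounds fluoro stands apart from both methyl and methoxy, which cannot be told apart from each other. The value of compound 4 is a limit of the assay, so both steps fix only a lower bound on their size: the limit of > 40000 nM in this assay, at which 2 of the 4 values shown sit.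

The compounds shown leave open whether an amine, a chloro group or a longer chain such as ethoxy at this position would keep the number near that of compound 3 or lower it.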